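Methoxybenzyl in Place of Benzodioxinylmethyl on a Shared Core

A few compounds are considered here, and "the series" means these few. Any claim that something is new, unique, unknown or untested is made for them only; others in the source may bear on it.

Three measured compounds share one core. In a functional assay on Capan-2 cells (Homo sapiens) for inhibition, read by MTT assay, with a stated time of 72 h (a higher number here means a weaker inhibitor of growth, a lower number a stronger inhibitor of growth), compound 1 `O=S(=O)(NCCNCc1ccc(-c2ccccc2)cc1)c1cc(C(F)(F)F)cc(C(F)(F)F)c1` gives 2400 nM. In this assay compound 3 `O=S(=O)(NCCCNCc1ccc(-c2ccccc2)cc1)c1cc(C(F)(F)F)cc(C(F)(F)F)c1` gives 2200 nM. Compound 2 `O=S(=O)(NCCCNCC1COc2ccccc2O1)c1cc(C(F)(F)F)cc(C(F)(F)F)c1` gives 2500 nM in this assay, the highest of the three numbers, though its gaps to compound 1 and to compound 3 both lie within the scatter, so no order among the three can be read. Compound 4 `COc1cccc(CNCCCNS(=O)(=O)c2cc(C(F)(F)F)cc(C(F)(F)F)c2)c1` has not been measured; it differs from compound 2 by 3-methoxyphenyl in place of 2,3-dihydro-1,4-benzodioxin-2-yl on a saturated chain carbon bound to an amine nitrogen. Within the data shown here, no measured pair isolates such a change, and the three measured values sit close together despite different groups at that place. The step of no change at the digits printed from compound 2 to compound 4 (within the scatter) is therefore expected to stay within the scatter. Compound 4 is expected to give 2500 nM in this assay, within 1200 nM to 5500 nM.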

Compound 4, concentration for 50% growth inhibition: 6400 nM
Estimate against measurement, compound 4: 2.6-fold (0.41 log units) below; the whole stated range lies below it.
By their numbers in this assay, from the lowest: compounds 3, 1 and 2 (each within the scatter of the next); then compound 4.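

In this assay the place on a saturated chain carbon bound to an amine nitrogen is not indifferent: 3-methoxyphenyl in place of 2,3-dihydro-1,4-benzodioxin-2-yl gives a 2.6-fold higher number from compound 2 to compound 4 (0.41 log units; beyond the scatter) in this one-place change. Among these compounds, this is the only step read here that lies beyond the scatter, and compound 4 has the highest number of the four compounds. The data offer no measured explanation for this step.

From the compounds shown here alone, whether the step follows from losing the non-aromatic ring or from the methoxy group itself remains open. A plain benzyl group at this place would separate these two readings.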